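Replacing a fluorine-bearing ring with a sulfonyl-bearing ring

The source may hold more compounds than are shown below. What is called first, only, known or untested is meant among the compounds shown, and "the series" means these compounds.

This account follows a series sharing one core, tested in a functional assay on MCF7 cells (Homo sapiens) for antiproliferative activity, read by CellTiter-Glo, with a stated time of 5 days; a higher number here means a weaker inhibitor, a lower number a stronger inhibitor. Compound 1 `CC1=C(c2cccc(F)c2)C(c2ccc(OC[C@H](C)N3CC[C@@H](C)C3)cc2)Oc2ccc(O)cc21` is the starting point; in this assay compound 1 gives 1 nM. Compound 2 `CC1=C(c2cccc(O)c2)C(c2ccc(OC[C@@H](C)N3CC[C@H](C)C3)cc2)Oc2ccc(O)cc21` carries a hydroxyl instead of the fluorine on the pendant ring, and compound 2 gives 0.2 nM. Compound 3 `CC1=C(c2cccc(O)c2)C(c2ccc(OC[C@H](C)N3CC[C@@H](C)C3)cc2)Oc2cc(O)ccc21` places its core hydroxyl differently, and compound 3 gives 0.3 nM. Among these three numbers compound 1 stands highest: its nearest neighbour is compound 3, whose number is lower by a margin beyond the usual scatter, and compound 2 sits further below it still.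

The next compound, compound 4 `CC1=C(c2ccc(S(C)(=O)=O)cc2)C(c2ccc(OC[C@H](C)N3CC[C@@H](C)C3)cc2)Oc2ccc(O)cc21`, is reached from compound 1 by one change on the double-bonded ring carbon of the core: 4-(methylsulfonyl)phenyl in place of 3-fluorophenyl on a double-bonded ring carbon. The entering group brings two hydrogen-bond acceptors and two double bonds outside aromatic rings where the leaving group had none.

Within the data shown here, no measured pair shows the effect of such a group, so the expectation rests on compound 1 alone. The author expects the number to rise modestly, the step from compound 1 to compound 4 being a 3.0-fold higher number from compound 1 to compound 4 (0.48 log units; beyond the scatter), somewhat beyond the scatter. For compound 4 the estimate in this assay is 3 nM, with a range from 0.7 nM to 15 nM.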

Compound 4, half-maximal inhibitory concentration: 27 nM
Estimate against measurement, compound 4: 9.0-fold (0.95 log units) below, and the stated range ends below it.
By their numbers in this assay, from the lowest: compounds 2 and 3 (each within the scatter of the next); then compound 1; then compound 4.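

In this assay, putting 4-(methylsulfonyl)phenyl in place of 3-fluorophenyl on the double-bonded ring carbon gives a 27-fold higher number from compound 1 to compound 4 (1.43 log units; beyond the scatter), a large step beyond the scatter and the first in this series to isolate a single place, so the number clearly depends on what this ring carbon carries when the rest of compound 1 stays fixed. The step does not separate two changes, however, since the group on the pendant ring and the number in its name both differ between 3-fluorophenyl and 4-(methylsulfonyl)phenyl. Nothing available here accounts for the size of the step.

The compounds shown leave open whether the group or its placing on the pendant ring matters more, a question that 3-(methylsulfonyl)phenyl and 4-fluorophenyl on the same core could answer in this assay. They also leave open how other groups on the pendant ring, such as a 4-aminophenyl or a 4-carboxyphenyl, would stand against compound 1 and compound 4.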